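Swapping a thiophene ring for phenyl in a nitrile series

The source may report more compounds than this note shows. Statements on the series, on what has been measured and on what is new or still open speak of the compounds shown alone.

Compound 1, drawn as `N#Cc1ccc(N2CCc3cc(-c4cnc5ccccc5c4)ccc3C2)cc1C(F)(F)F`, was tested in a functional assay on VCaP cells (Homo sapiens) for antiproliferative activity, read by CCK-8 assay, with a stated time of 6 days; on this read-out lower numbers stand for stronger inhibition and higher numbers for weaker inhibition. In this assay compound 1 gives > 30000 nM, which is a limit of the assay rather than a number. Compound 2, `CCN(c1ccc(C#N)c(Cl)c1)c1cc(-c2cccs2)ccc1C`, has no number of its own here; for compound 2 the result in this assay reads "not determined" (no result reported). Among the measured compounds shown here, the only value shown is thus the limit (the limit of > 30000 nM in this assay, at which 1 of the 2 values shown sits). Compound 3, `CCN(c1ccc(C#N)c(Cl)c1)c1cc(-c2ccccc2)ccc1C`, differs from compound 2 as phenyl in place of thiophen-2-yl on an aromatic carbon. For the measured compounds named here, no measured step exists for this change, so no size or direction beyond the scatter can be claimed. Compound 3 is expected to give about 5000 nM, within 500 nM to 30000 nM.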

Compound 3, half-maximal inhibitory concentration: > 30000 nM
Compound 3: no number, only a limit (the forecaster's own chance of this, stated with the estimate: 35%); at least 6.0-fold (0.77 log units) between middle value and limit.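

No step can be read from compound 2 to compound 3: compound 2 has no number, and compound 3 has only a limit. The compounds shown leave open whether phenyl and thiophen-2-yl differ at all in this assay.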